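A few compounds are considered here, and "the series" means these few. Any claim that something is new, unique, unknown or untested is made for them only; others in the source may bear on it.

Compound 1 `Fc1ccc(C2CC(c3ccc(Cl)s3)=NN2c2nc(-c3ccc(Br)cc3)cs2)cc1` is the starting point of this small series. In a functional assay on A549 cells (Homo sapiens) for antiproliferative activity, read by XTT assay, with a stated time of 24 h (on this read-out higher numbers stand for weaker inhibition and lower numbers for stronger inhibition), compound 1 gives 62.5 ug/mL. Compound 2 `CS(=O)(=O)c1ccc(-c2csc(N3N=C(c4ccc(Cl)s4)CC3c3ccc(F)cc3)n2)cc1` carries a methylsulfonyl group where compound 1 carries bromo. In this assay compound 2 reaches only a limit of the assay, > 500 ug/mL, so no exact number is known for it. The change gives an at least 8.0-fold higher number from compound 1 to compound 2 (0.90 log units; beyond the scatter). Compound 2 therefore stands at the upper edge of what the assay can report, namely (the limit of > 500 ug/mL in this assay, at which 1 of the 2 values shown sits), and its true value may lie anywhere beyond that edge.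

Compound 3 `N#Cc1ccc(-c2csc(N3N=C(c4ccc(Cl)s4)CC3c3ccc(F)cc3)n2)cc1` is the next compound, not yet measured. It differs from compound 2 by cyano in place of methylsulfonyl on an aromatic carbon. For the measured compounds named here, only one measured step exists here, and it concerns methylsulfonyl entering in place of bromo; no measured step involves cyano, so the direction and size of the new step rest on little. Since the methylsulfonyl group leaves again, a lower number than the limit of compound 2 is expected, that is an at least 2.5-fold lower number from compound 2 to compound 3 (0.39 log units; beyond the scatter). Compound 3 is therefore estimated at 200 ug/mL, within a range from 60 ug/mL to 500 ug/mL.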

Compound 3, half-maximal inhibitory concentration: > 500 ug/mL
Compound 3 gave a limit, no number (the forecaster's own chance of this, stated with the estimate: 40%); middle value at least 2.5-fold (0.39 log units) away from the limit.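

In this assay, a second replacement of the bromo on this ring now points the same way as the first: cyano in place of bromo gives an at least 8.0-fold higher number from compound 1 to compound 3 (0.90 log units; beyond the scatter) at this same position, para to a large group. The rise in the number from compound 1 is therefore not tied to methylsulfonyl alone, since two different groups, one with a double-bonded sulfur and one with a triple-bonded carbon and nitrogen, both give it in this small set. The step between compound 2 and compound 3 cannot be read, and the two cannot be ranked, because both stop at the same edge of the assay: (the limit of > 500 ug/mL in this assay, at which 2 of the 3 values shown sit).

Of the three groups shown at this position, only bromo gives an exact number, so it stays open how far the number moves with any other group here, such as chloro, an amine or a carboxylic acid. From the compounds shown here alone, it also stays open whether any group at this position gives a lower number than compound 1 does, or whether bromo is close to the best that this position allows.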